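Cytotoxicity series: heteroaryl and biaryl amides with a hexanoic acid chain

A few compounds are considered here, and "the series" means these few. Any claim that something is new, unique, unknown or untested is made for them only; others in the source may bear on it.

Measured so far in an ADME assay on BJ cells (Homo sapiens) for cytotoxicity, read by CellTiter-Glo and resazurin assay, with a stated time of 72 h; on this read-out higher numbers stand for an effect only at larger amounts of compound and lower numbers for an effect already at smaller amounts:
- compound 1 `CC(C)N(Cc1cccc(OCCCCCC(=O)O)c1)C(=O)c1ccc(-c2cccc(-c3ccccc3)c2)cc1`: compound 1 gives a limit, > 26000 nM
- compound 2 `CC(C)N(Cc1cccc(OCCCCCC(=O)O)c1)C(=O)c1ccc(-c2ccoc2)cc1`: compound 2 gives a limit, > 26000 nM
- compound 3 `CC(C)N(Cc1cccc(OCCCCCC(=O)O)c1)C(=O)c1ccc(-c2ccsc2)cc1`: compound 3 gives a limit, > 26000 nM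

Compound 1 stands only at a limit in this assay, with no number of its own; the two other values shown are limits as well, so that no ordering among the three can be read. The steps between them are unreadable for the same reason: a step that the two limits leave unreadable from compound 1 to compound 2, a step that the two limits leave unreadable from compound 1 to compound 3 and a step that the two limits leave unreadable from compound 2 to compound 3. All three values sit at the same limit, (the limit of > 26000 nM in this assay, at which 3 of the 3 values shown sit).

Compound 4 `CC(C)N(Cc1cccc(OCCCCCC(=O)O)c1)C(=O)c1ccc(-c2cccc(OCc3ccccc3)c2)cc1` differs from compound 1 in one place: benzyloxy in place of phenyl on an aromatic carbon. For the measured compounds named here, none of the measured steps is readable, so no size can be carried over to this change; what the data do show is that three exchanges at the same position of the shared core left every compound at the limit. The expectation for compound 4 is therefore that it again shows no effect below the limit, with the step from compound 1 to compound 4 estimated as a step that the limit leaves unreadable from compound 1 to compound 4. For compound 4 in this assay the estimate is 40000 nM, with a range from 20000 nM to 120000 nM.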

Compound 4, half-maximal effective concentration: > 26000 nM
Compound 4: no number, only a limit; the forecaster's own chance of this, stated with the estimate: 85%; the middle value does not contradict the limit.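

In this assay compound 4 gives > 26000 nM as a limit, not a number. For the compounds shown here, no step from compound 1 to compound 4 can be read, since both compounds stand only at a limit: the limit of > 26000 nM in this assay, at which 4 of the 4 values shown sit. The compounds shown leave open at what concentration any of them would show an effect, and whether any exchange at this position of the shared core would give a readable value.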